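Aryl group changes on the shared core: compound 2 to compound 4

This account rests on a few compounds, and the source may have more. Where it says the series, first, only, none or still open, it means among the compounds named here.

compound 1 `O=C(O)CC/C=C\CC1COC(c2ccccc2Cl)OC1c1cccnc1`: 759 nM
compound 2 `O=C(O)CC/C=C\CC1COC(c2ccc([N+](=O)[O-])cc2)OC1c1cccnc1`: 933 nM
compound 3 `O=C(O)CC/C=C\CC1COC(c2ccc(C(F)(F)F)cc2)OC1c1cccnc1`: 1780 nM

All three values come from a functional assay for inhibition, with Homo sapiens as the target; a higher number here means weaker binding, a lower number tighter binding. In this assay compound 2, at 933 nM, cannot be separated from either of the other measured compounds: the steps are a 1.2-fold higher number from compound 1 to compound 2 (0.09 log units; within the scatter) and a 1.9-fold higher number from compound 2 to compound 3 (0.28 log units; within the scatter). Compound 4 `O=C(O)CC/C=C\CC1COC(c2ccsc2)OC1c1cccnc1`, not yet measured, has thiophen-3-yl in place of 4-nitrophenyl on a saturated ring carbon, between two ring oxygen atoms (thiophen-3-yl in place of 4-nitrophenyl on a saturated ring carbon).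

All three measured steps change the group at this same carbon. Only one passes the scatter, and it is modest: a 2.3-fold higher number from compound 1 to compound 3 (0.37 log units; beyond the scatter). Going by the values given here, none of the measured compounds has a five-membered aromatic ring here, so the read-across is loose. On these steps, no change beyond the scatter is expected in this assay, and no direction is favoured. The expected step is a 1.0-fold lower number from compound 2 to compound 4 (0.02 log units; within the scatter). For compound 4 the estimated value is 900 nM, with an expected range of 350 nM to 2300 nM.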

Compound 4, dissociation constant: 1580 nM
The estimate for compound 4 lay 1.8-fold (0.24 log units) below the measured number; low and high end bracket the measured number.
By their numbers in this assay, from the lowest: compounds 1, 2, 4 and 3 (each within the scatter of the next, the first and the last beyond it).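

In this assay, a five-membered aromatic ring with one hetero atom on the saturated ring carbon between the two ring oxygen atoms cannot be separated from the six-membered aryl groups at para-free positions of the series: a 1.7-fold higher number from compound 2 to compound 4 (0.23 log units; within the scatter) and a 1.1-fold lower number from compound 3 to compound 4 (0.05 log units; within the scatter) both stay within the scatter. Only a 2.1-fold higher number from compound 1 to compound 4 (0.32 log units; beyond the scatter) passes the scatter, and that step is modest; compound 1, with 2-chlorophenyl, now stands apart from compound 3 and compound 4 but still not from compound 2. No measurement bearing on the reason for these differences is available.

Open, from the compounds shown here alone, is how a furan-3-yl, a pyridin-3-yl or a cyclohexyl group would read at this carbon. Also open, going by these compounds, is whether a 4-chlorophenyl group would stay with compound 1 or fall in with compound 3 and compound 4.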